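Methoxymethyl for cyclopropyl on the piperidine carboxamide

The source may hold more compounds than are shown below. What is called first, only, known or untested is meant among the compounds shown, and "the series" means these compounds.

Of the compounds shown here, three sharing one core have been measured in an assay on isolated protein for displacement of a labelled ligand from Adrenergic receptor alpha-1 (Rattus norvegicus); a higher number here means a weaker inhibitor, a lower number a stronger inhibitor. Compound 1 `CCNC(=O)C1CCN(c2nc(N)c3cc(OC)c(OC)cc3n2)CC1` gives 1.64 nM, compound 2 `COc1cc2nc(N3CCC(C(=O)NC4CCCC4)CC3)nc(N)c2cc1OC` gives 0.63 nM, and compound 3 `COc1cc2nc(N3CCC(C(=O)NCC4CC4)CC3)nc(N)c2cc1OC` gives 0.9 nM; all three lie within the scatter of one another, so compound 3 cannot be separated from either neighbour. The steps into compound 3 were small: a 1.8-fold lower number from compound 1 to compound 3 (0.26 log units; within the scatter) and a 1.4-fold higher number from compound 2 to compound 3 (0.15 log units; within the scatter), while only a 2.6-fold lower number from compound 1 to compound 2 (0.42 log units; beyond the scatter) reached beyond the scatter. Compound 4 `COCCNC(=O)C1CCN(c2nc(N)c3cc(OC)c(OC)cc3n2)CC1` differs from compound 3 by methoxymethyl in place of cyclopropyl on a saturated chain carbon bound to an amide-type nitrogen. Within the data shown here, no measured step carries a methoxymethyl, but every change on this amide nitrogen so far stayed small, so compound 4 is expected to show a 1.4-fold higher number from compound 3 to compound 4 (0.16 log units; within the scatter) in this assay, not beyond the scatter. Compound 4 is therefore estimated at 1.3 nM, within 0.5 nM to 3.5 nM.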

Compound 4, inhibition constant: 1.13 nM
Compound 4: middle estimate off by 1.2-fold (0.06 log units), on the high side; the measured number falls inside the stated range.
By their numbers in this assay, from the lowest: compounds 2, 3, 4 and 1 (each within the scatter of the next, the first and the last beyond it).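

In this assay, the 2-methoxyethyl of compound 4, which brings a hydrogen-bond acceptor and no ring, cannot be separated from cyclopropylmethyl (a 1.3-fold higher number from compound 3 to compound 4 (0.10 log units; within the scatter)). Nor can it be separated from cyclopentyl (a 1.8-fold higher number from compound 2 to compound 4 (0.25 log units; within the scatter)) or from ethyl (a 1.5-fold lower number from compound 1 to compound 4 (0.16 log units; within the scatter)). An open chain holding oxygen therefore sits among the ring-bearing and plain alkyl amides at this position, even though compound 1 and compound 2 lie beyond the scatter of each other. From the compounds shown here alone, whether an amine or a carboxylic acid at the end of this chain would stay in the same range remains open. No other data bear on this result.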